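Sulfonyl aryl swap: dimethoxyphenyl replacing aminobromophenyl

The source may report more compounds than this note shows. Statements on the series, on what has been measured and on what is new or still open speak of the compounds shown alone.

In an assay on brain for displacement of a labelled ligand from 5-hydroxytryptamine receptor 4 (Cavia porcellus), with a stated time of 30 min, in the presence of a further agent that is not named here (on this read-out lower numbers stand for stronger inhibition and higher numbers for weaker inhibition), compound 2 `COc1cc(N)c(Cl)cc1C(=O)CCC1CCN(CCNS(=O)(=O)c2ccc(N)c(Br)c2)CC1` gives 5.3 nM, the lowest number of the two measured, with compound 1 `COc1ccc(S(=O)(=O)NCCN2CCC(CCC(=O)c3cc(Cl)c(N)cc3OC)CC2)cc1Cl` at 22.5 nM. Going by the values given here, the only measured step, a 4.2-fold lower number from compound 1 to compound 2 (0.63 log units; beyond the scatter), also changed the aryl on the sulfonyl sulfur, from a methoxy-bearing ring to the amino-bearing one. Compound 3 `COc1ccc(S(=O)(=O)NCCN2CCC(CCC(=O)c3cc(Cl)c(N)cc3OC)CC2)c(OC)c1` carries 2,4-dimethoxyphenyl in place of 4-amino-3-bromophenyl on a sulfonyl sulfur. This removes the donor that compound 2 has and returns to a methoxy-substituted ring like compound 1, so a modest rise in this assay is expected, of the order of a 3.8-fold higher number from compound 2 to compound 3 (0.58 log units; beyond the scatter). Compound 3 is therefore estimated at 20 nM, within 7 nM to 55 nM.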

Compound 3, inhibition constant: 18.7 nM
Compound 3: middle estimate off by 1.1-fold (0.03 log units), on the high side, and the stated range covers the measured number.
By their numbers in this assay, from the lowest: compound 2; then compounds 3 and 1 (each within the scatter of the next).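

In this assay, 2,4-dimethoxyphenyl on the sulfonyl sulfur does not keep the lower number seen with 4-amino-3-bromophenyl (a 3.5-fold higher number from compound 2 to compound 3 (0.55 log units; beyond the scatter)). Set against 3-chloro-4-methoxyphenyl, the same group shows no separation (a 1.2-fold lower number from compound 1 to compound 3 (0.08 log units; within the scatter)), so among these three aryl groups only the one in compound 2 stands apart. No measurement here gives a reason for this.

Which part of 4-amino-3-bromophenyl carries the difference stays open. An aminophenyl without the bromine and a bromophenyl without the amine would separate the two.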